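Opening a Ring Amine into a Chain Amine

The compounds below may be only part of what the source reports. "The series", "measured", "known", "first", "only" and "open" are said of these compounds alone.

Of the compounds shown here, three that share one core have been measured in a functional assay on SK-BR-3 cells (Homo sapiens) for antiproliferative activity; a lower number here means a stronger inhibitor, a higher number a weaker inhibitor. Compound 1 `CC(C)=CCc1cc(C(=O)Nc2cc3ccc(OCC4CCCN(C)C4)c(C)c3oc2=O)ccc1O` gives 1300 nM. Compound 2 `CC(C)=CCc1cc(C(=O)Nc2cc3ccc(OCC4CCN(C)C4)c(C)c3oc2=O)ccc1O` gives 920 nM. Compound 3 `CCNCCCOc1ccc2cc(NC(=O)c3ccc(O)c(CC=C(C)C)c3)c(=O)oc2c1C` gives 720 nM. Compound 2 stands second highest of the three numbers, and every step between them is small: a 1.4-fold lower number from compound 1 to compound 2 (0.15 log units; within the scatter), a 1.8-fold lower number from compound 1 to compound 3 (0.26 log units; within the scatter) and a 1.3-fold lower number from compound 2 to compound 3 (0.11 log units; within the scatter) all stay within the scatter. The three tail groups, each hanging from a saturated chain carbon bound to an oxygen on an aromatic ring, therefore cannot be told apart on these numbers.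

Compound 4 `CC(C)=CCc1cc(C(=O)Nc2cc3ccc(OCCCNC(C)(C)C)c(C)c3oc2=O)ccc1O` has not yet been measured. It differs from compound 2 in one place: 2-((tert-butyl)amino)ethyl in place of 1-methylpyrrolidin-3-yl on a saturated chain carbon bound to an oxygen on an aromatic ring. A five-membered non-aromatic ring gives way to a group with no ring. Going by the values given here, the closest precedent is the exchange of 1-methylpyrrolidin-3-yl for another chain amine, 2-(ethylamino)ethyl, where a 1.3-fold lower number from compound 2 to compound 3 (0.11 log units; within the scatter) stayed within the scatter; the exchange of 1-methylpiperidin-3-yl for that same chain, a 1.8-fold lower number from compound 1 to compound 3 (0.26 log units; within the scatter), did the same. Compound 4 is therefore expected to show a 1.2-fold lower number from compound 2 to compound 4 (0.09 log units; within the scatter), a step within the scatter. The estimate for compound 4 in this assay is 750 nM, within a range from 350 nM to 1600 nM.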

Compound 4, half-maximal inhibitory concentration: 660 nM
For compound 4 the middle estimate is 1.1-fold (0.06 log units) above the measured one; measured number inside the range.
By their numbers in this assay, from the lowest: compounds 4, 3, 2 and 1 (each within the scatter of the next).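

The new information concerns the amine nitrogen of the chain itself: in this assay, placing tert-butyl instead of ethyl on that nitrogen gives a 1.1-fold lower number from compound 3 to compound 4 (0.04 log units; within the scatter), so these two groups cannot be told apart on this number. Opening the ring to this new chain amine gives a 1.4-fold lower number from compound 2 to compound 4 (0.14 log units; within the scatter) from the five-membered ring and a 2.0-fold lower number from compound 1 to compound 4 (0.29 log units; within the scatter) from the 1-methylpiperidin-3-yl group, so a second chain amine joins the first in showing no readable difference from either ring, even in the largest step among the four compounds. No independent measurement is available to explain why these tails read alike.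

Going by these compounds, all four tails carry an amine nitrogen, so it remains open whether this nitrogen matters at all, a question that a tail ending in a hydroxyl group or a carboxylic acid could address. Also open, on these data alone, is how far the position tolerates change in the chain itself, which a longer chain carrying the same tert-butyl amine could test.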